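The source may report more compounds than this note shows. Statements on the series, on what has been measured and on what is new or still open speak of the compounds shown alone.

Four compounds share the same arrangement: a saturated nitrogen ring that carries a five-membered aromatic ring bearing a fluorophenyl group on one side and an amide on the other, and they differ in what sits on the carbonyl carbon of that amide and in the size of the saturated ring. They were tested in an in vitro functional assay on HEK293-A cells for positive allosteric modulation of metabotropic glutamate receptor 5 (Homo sapiens), read by fluorescence and calcium flux, with a stated time of 140 s; on this read-out higher numbers stand for an effect only at larger amounts of compound and lower numbers for an effect already at smaller amounts.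

Compound 1 `O=C(C1CCCCC1)N1CCCC[C@@H]1c1nc(-c2cccc(F)c2)no1` gives 3500 nM. Compound 2 `O=C(c1ccc(F)c(F)c1)N1CCCC[C@@H]1c1nc(-c2cccc(F)c2)no1` gives 1400 nM. The two differ by 3,4-difluorophenyl in place of cyclohexyl on a carbonyl carbon, and the change brought a 2.5-fold lower number from compound 1 to compound 2 (0.40 log units; beyond the scatter).

Compound 3 `O=C(C1CCCCC1)N1CCCC1c1nc(-c2cccc(F)c2)no1` carries a smaller saturated ring; the difference between the two cores is not broken down here. In this assay compound 3 gives 10000 nM, the highest number among the three measured compounds.

Compound 4 `O=C(c1ccc(F)c(F)c1)N1CCCC1c1nc(-c2cccc(F)c2)no1` has not yet been measured. Compared with compound 3 it shows (3,4-difluorophenyl in place of cyclohexyl on a carbonyl carbon), which is the same change as the one from compound 1 to compound 2, at the same kind of place, since both descriptions of the place read alike: a carbonyl carbon whose other neighbour is an amide-type nitrogen in a ring.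

If the change behaves on the smaller core as it did on the larger one, compound 4 is expected to show a 2.5-fold lower number from compound 3 to compound 4 (0.40 log units; beyond the scatter), resting on compound 3 at 10000 nM and on the earlier step of a 2.5-fold lower number from compound 1 to compound 2 (0.40 log units; beyond the scatter). The estimate for compound 4 is therefore 4000 nM, expected between 1800 nM and 10000 nM.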

Compound 4, half-maximal effective concentration: 3700 nM
Beside the measured number, compound 4's estimate is 1.1-fold (0.03 log units) above it; measured number inside the range.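

Putting 3,4-difluorophenyl in place of cyclohexyl on the carbonyl carbon gave a 2.7-fold lower number from compound 3 to compound 4 (0.43 log units; beyond the scatter) in this assay, so on the core with the smaller saturated ring the change lowered the number much as it did on the larger one. The two steps can be treated as the same size: the same change on two cores in this assay, a 2.5-fold lower number (0.40 log units; beyond the scatter) from compound 1 to compound 2 and a 2.7-fold lower number (0.43 log units; beyond the scatter) from compound 3 to compound 4, 1.1-fold (0.03 log units) apart, within the scatter of two such steps. This shows that, for this one pair of groups in this one assay, the gain carried from one core to the other and the step measured on one core was a fair guide to the step on the other, but it rests on just two pairs of compounds, so it is no general rule for other cores and it does not explain why the steps match.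

The compounds shown hold only cyclohexyl and 3,4-difluorophenyl on the carbonyl carbon, so it stays open whether another group there, such as an unsubstituted phenyl, an amine or a longer chain, would also shift the number by a similar amount on both cores. The fluorophenyl group is also the same in all four compounds, which leaves open whether the match between the two cores would hold with a different group in its place, such as a methoxyphenyl.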